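A few compounds are considered here, and "the series" means these few. Any claim that something is new, unique, unknown or untested is made for them only; others in the source may bear on it.

Compound 1, with the structure `O=[N+]([O-])c1cccc(CNc2cc(Br)cc3[nH]ncc23)c1`, gives 97% in an assay for inhibition of Tryptophan 2,3-dioxygenase (Homo sapiens), with stated times of 10 min and 60 min, tested at 100 uM; a higher number here means a stronger effect of the compound at the concentration tested, a lower number a weaker effect. Going by the values given here, compound 2, with the structure `O=[N+]([O-])c1cccc(CNc2cc(C(F)(F)F)cc3[nH]ncc23)c1`, gives 82% in this assay, and so stands as the lower of the two numbers measured; the only step known is a number 15 percentage points lower from compound 1 to compound 2 (beyond the scatter), a change that moved the reading by a modest amount beyond the scatter.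

Compound 3, with the structure `OC1CCCC(Nc2cccc(CNc3cc(C(F)(F)F)cc4[nH]ncc34)c2)C1`, has not yet been measured. It differs from compound 2 in one place: (3-hydroxycyclohexyl)amino in place of nitro on an aromatic carbon. Among the compounds with values here, no measured step involves this kind of exchange, since the only step known concerns a different position, so there is no direct guide to its size or direction. Compound 3 is therefore expected to give about 70% in this assay, within a wide range from 40% to 95%. That estimate means an expected step of a number 12 percentage points lower from compound 2 to compound 3 (beyond the scatter).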

Compound 3, a percentage reported as inhibition, at one concentration (the size of the read-out at that concentration, not a potency): 23%
Beside the measured number, compound 3's estimate is 47 percentage points above it; measured number outside the range, below it.
By their numbers in this assay, from the lowest: compound 3; then compound 2; then compound 1.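

Going by these compounds alone, the nitro-bearing position turns out to matter more than the single earlier step could show. In this assay, putting (3-hydroxycyclohexyl)amino in place of nitro gives a number 59 percentage points lower from compound 2 to compound 3 (beyond the scatter), a large step, whereas a number 15 percentage points lower from compound 1 to compound 2 (beyond the scatter), at the other position, is modest. No measurement shown here accounts for this drop.

The compounds shown leave open which part of the entering group goes with the drop, since the linking amine, the six-membered carbon ring and the hydroxyl all arrive together in one exchange. They also leave open how a plain amine or a cyclohexylamino group without the hydroxyl would read at this position, and whether the same exchange would cost as much with bromo in place of trifluoromethyl.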